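The source may report more compounds than this note shows. Statements on the series, on what has been measured and on what is new or still open speak of the compounds shown alone.

Working notes on the brominated diaryl ether series, chain at the aromatic oxygen.

Three compounds are measured and all differ only in the group on the aromatic oxygen of the shared core. Compound 1 `BrCCCOc1c(Br)cc(Br)cc1Oc1ccc(Br)cc1Br` gives 29.9 ug/mL in a functional assay on HL-60 cells (Homo sapiens) for cytotoxicity, read by MTT assay, with a stated time of 24 h; a lower number here means a stronger inhibitor, a higher number a weaker inhibitor. Compound 2 `CC(C)(C)OC(=O)N1CCN(CCCCCOc2c(Br)cc(Br)cc2Oc2ccc(Br)cc2Br)CC1` gives 32.1 ug/mL and compound 3 `CN1CCN(CCCCCOc2c(Br)cc(Br)cc2Oc2ccc(Br)cc2Br)CC1` gives 48.3 ug/mL. Compound 1 holds the lowest of the three numbers, but its gaps to compound 2 and compound 3 are within the scatter, so the three sit together rather than in an order. Among the measured compounds shown here, the one step that alters the chain end, a 1.6-fold higher number from compound 1 to compound 3 (0.21 log units; within the scatter), stayed within the scatter; so did a 1.5-fold higher number from compound 2 to compound 3 (0.18 log units; within the scatter), which only swaps the group on the ring nitrogen.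

Compound 4 `CC(C)(C)C(=O)C(C#N)Oc1c(Br)cc(Br)cc1Oc1ccc(Br)cc1Br` is not yet measured. Against compound 1 the change is cyano((tert-butyl)carbonyl)methyl in place of 3-bromopropyl on an oxygen on an aromatic ring. For the measured compounds named here, only the step from compound 1 to compound 3 bears on this, since it too replaces what hangs on the aromatic oxygen, and it moved nothing beyond the scatter. Cyano((tert-butyl)carbonyl)methyl has no precedent in the set, so the expectation rests on that single step and is loose. The expected step is a 1.0-fold higher number from compound 1 to compound 4 (0.00 log units; within the scatter), that is, nothing beyond the scatter. Compound 4 is estimated at 30 ug/mL, within a range of 12 ug/mL to 75 ug/mL.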

Compound 4, half-maximal inhibitory concentration: 29.2 ug/mL
Compound 4: the middle estimate sits 1.0-fold (0.01 log units) above what was measured; measured number inside the range.
By their numbers in this assay, from the lowest: compounds 4, 1, 2 and 3 (each within the scatter of the next).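

In this assay the exchange on the oxygen on an aromatic ring gives a 1.0-fold lower number from compound 1 to compound 4 (0.01 log units; within the scatter) and so stays within the scatter, even though cyano((tert-butyl)carbonyl)methyl, with 9 heavy atoms, 1 double bond and 1 triple bond outside aromatic rings and 2 hydrogen-bond acceptors, replaces 3-bromopropyl, with 4 heavy atoms and no hydrogen-bond acceptors. Until now the only change at this place had been a chain ending in a piperazine ring, so this result extends the finding to an entering group with no ring, and no compound shown goes against the flat picture at this oxygen. Nothing measured on these compounds accounts for the absence of a shift, and the flat picture remains a description of the numbers alone.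

Still open is whether any group on this oxygen can move the number beyond the scatter in either direction, since no step shown does so. The free phenol, a carboxylic acid on a short chain or a primary amine at the chain end would each test this at the same place on the shared core.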